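Extending the methoxy group: an estimate for compound 4

The source may report more compounds than this note shows. Statements on the series, on what has been measured and on what is new or still open speak of the compounds shown alone.

Compound 1, `Brc1cncc(N2CC[C@H]3CN[C@H]3C2)c1`: 150 nM
Compound 2, `N#Cc1cncc(N2CC[C@H]3CN[C@H]3C2)c1`: 1900 nM
Compound 3, `COc1cncc(N2CC[C@H]3CN[C@H]3C2)c1`: 130 nM

Of the compounds shown here, three sharing one core have been measured in a functional assay on HEK293 cells for agonist activity at Neuronal acetylcholine receptor; alpha4/beta2 (Homo sapiens), read by FLIPR; on this read-out lower numbers stand for an effect already at smaller amounts and higher numbers for an effect only at larger amounts of compound. Compound 3 and compound 1 lie within the scatter of each other, the step of a 1.2-fold lower number from compound 1 to compound 3 (0.06 log units; within the scatter) being small, while compound 2 stands well apart from both: a 13-fold higher number from compound 1 to compound 2 (1.10 log units; beyond the scatter) and a 15-fold lower number from compound 2 to compound 3 (1.16 log units; beyond the scatter) are both large. So the numbers seen so far say that bromo and methoxy on the aromatic carbon behave alike in this assay, and cyano does not.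

Compound 4, `CCOc1cncc(N2CC[C@H]3CN[C@H]3C2)c1`, has not yet been measured. It differs from compound 3 by methyl in place of hydrogen on a saturated chain carbon bound to an oxygen on an aromatic ring. Among the measured compounds shown here, none of the measured steps touches this position: each of them swaps the group on the aromatic carbon itself, whereas this change lengthens the chain beyond the oxygen. The closest guide is that the small step of a 1.2-fold lower number from compound 1 to compound 3 (0.06 log units; within the scatter) shows the assay tolerating different groups at that site, which gives no reason to expect a large shift from a single added carbon. The expected step is therefore a 1.4-fold higher number from compound 3 to compound 4 (0.14 log units; within the scatter), within or close to the scatter. Compound 4 is estimated at 180 nM, with a range from 70 nM to 500 nM.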

Compound 4, half-maximal effective concentration: 620 nM
Compound 4: middle estimate off by 3.4-fold (0.54 log units), on the low side; the whole stated range lies below it.
By their numbers in this assay, from the lowest: compounds 3 and 1 (each within the scatter of the next); then compound 4; then compound 2.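

In this assay, the chain beyond the oxygen proves to be a sensitive part of the molecule: changing methoxy to ethoxy, with methyl in place of hydrogen on a saturated chain carbon bound to an oxygen on an aromatic ring, gives (a 4.8-fold higher number from compound 3 to compound 4 (0.68 log units; beyond the scatter)), a modest step beyond the scatter. Ethoxy also separates from bromo (a 4.1-fold higher number from compound 1 to compound 4 (0.62 log units; beyond the scatter)) but does not reach cyano (a 3.1-fold lower number from compound 2 to compound 4 (0.49 log units; beyond the scatter)), so compound 4 falls between the close pair of compound 3 and compound 1 and the much higher compound 2, showing that the similarity of bromo and methoxy did not extend to this longer group. Nothing available here accounts for the effect of the added methyl.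

On these data alone, it remains open whether a propoxy or butoxy chain would move the number further in the same direction, or whether a branched isopropoxy group would behave like ethoxy. Also unresolved is whether an amine or a hydroxyl group at the end of the chain would change the step, and whether methoxy to ethoxy would give a step of similar size on another core.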